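A Methoxyphenyl Variant of Compound 1 Awaits Measurement

The source may report more compounds than this note shows. Statements on the series, on what has been measured and on what is new or still open speak of the compounds shown alone.

Of the compounds shown here, two sharing one core have been tested in an assay on isolated protein for inhibition of histone deacetylase 8 (Homo sapiens), with a stated time of 1 h; a higher number here means a weaker inhibitor, a lower number a stronger inhibitor. Compound 1 `Cc1ccc(NC(=O)COc2ccc3cc(/C=C4/SC(=O)NC4=O)ccc3c2)cc1` gives 9000 nM in this assay. Compound 2 `CCOc1ccc2nc(NC(=O)COc3ccc4cc(/C=C5/SC(=O)NC5=O)ccc4c3)sc2c1` gives 17000 nM in this assay, and the two numbers lie within the usual scatter of each other, so neither compound can be set apart from the other on these data. For the measured compounds named here, no pair of compounds differing in a single place has been measured, so no step of known size is available.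

Compound 3 `COc1cccc(NC(=O)COc2ccc3cc(/C=C4/SC(=O)NC4=O)ccc3c2)c1` has not yet been measured. It differs from compound 1 in one place: 3-methoxyphenyl in place of 4-methylphenyl on an amide-type nitrogen. The two measured compounds carry very different groups on that amide-type nitrogen and still give numbers that cannot be told apart, which suggests that this position tolerates change without a large shift in this assay. On that basis compound 3 is expected to sit close to compound 1, with a step of a 1.1-fold higher number from compound 1 to compound 3 (0.05 log units; within the scatter) that is not expected to go beyond the scatter in either direction. The estimate for compound 3 in this assay is 10000 nM, with a range from 3000 nM to 35000 nM.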

Compound 3, half-maximal inhibitory concentration: 7600 nM
Beside the measured number, compound 3's estimate is 1.3-fold (0.12 log units) above it, and the stated range covers the measured number.
By their numbers in this assay, from the lowest: compounds 3, 1 and 2 (each within the scatter of the next, the first and the last beyond it).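

With compound 3, the series gains its first measured pair differing in one place, and in this assay the exchange of 4-methylphenyl for 3-methoxyphenyl on the amide-type nitrogen gives a 1.2-fold lower number from compound 1 to compound 3 (0.07 log units; within the scatter). This single change adds one oxygen and one hydrogen-bond acceptor by the count of the two groups and keeps the six-membered aromatic ring of carbon, yet it leaves the two compounds indistinguishable in this measurement, so this particular exchange at this position can be said to produce no shift that the assay can resolve. No measured information is available to explain this outcome.

The compounds shown leave open whether the same holds for a group of another kind at this position, such as a phenyl ring carrying an amine or a carboxylic acid, or a longer chain in place of the ring. They also leave open whether 4-methoxyphenyl on the same nitrogen would match 3-methoxyphenyl, and whether any change to the shared core would move the number further than these exchanges on the amide-type nitrogen.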